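This account rests on a few compounds, and the source may have more. Where it says the series, first, only, none or still open, it means among the compounds named here.

Working notes on the series.

Compound 1 `CCO/N=C1/C(=O)N(CCCn2cc(CN3CCC[C@@H]4CN(c5c(F)cc6c(=O)c(C(=O)O)cn(C7CC7)c6c5OC)C[C@@H]43)nn2)c2ccccc21` is the reference point in an ADME assay on Vero cells (Chlorocebus sabaeus) for cytotoxicity, read by MTT assay, with a stated time of 72 h (on this read-out higher numbers stand for lower toxicity in this test and lower numbers for higher toxicity in this test), where compound 1 gives 16 ug/mL. Compound 2 `COc1c(N2C[C@H]3CCCN(Cc4cn(CCCN5C(=O)/C(=N/O)c6ccccc65)nn4)[C@H]3C2)c(F)cc2c(=O)c(C(=O)O)cn(C3CC3)c12` carries hydrogen in place of ethyl on an oxygen; in this assay compound 2 gives 8 ug/mL. The step of a 2.0-fold lower number from compound 1 to compound 2 (0.30 log units; within the scatter) is within the scatter, so the two compounds are not separated by this read-out. Among the compounds with values here, of the two numbers recorded, that of compound 2 is the lower, with compound 1 as its only neighbour.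

Compound 3 `CO/N=C1/C(=O)N(CCCn2cc(CN3CCC[C@@H]4CN(c5c(F)cc6c(=O)c(C(=O)O)cn(C7CC7)c6c5OC)C[C@@H]43)nn2)c2ccccc21` differs from compound 2 by methyl in place of hydrogen on an oxygen. Within the data shown here, the only measured step that bears on this change is a 2.0-fold lower number from compound 1 to compound 2 (0.30 log units; within the scatter), which covers the same oxygen in the opposite sense, ethyl leaving and hydrogen entering, and it stayed within the scatter. Going back from hydrogen to an alkyl group, here methyl, is therefore expected to give at most a small step in this assay, if any, in the direction of a somewhat higher number, but not beyond the scatter.

The estimate for compound 3 in this assay is 12 ug/mL, with a range from 6 ug/mL to 24 ug/mL, which corresponds to an expected step of a 1.5-fold higher number from compound 2 to compound 3 (0.18 log units; within the scatter).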

Compound 3, half-maximal cytotoxic concentration: 16 ug/mL
For compound 3 the middle estimate is 1.3-fold (0.12 log units) below the measured one; the measured number falls inside the stated range.
By their numbers in this assay, from the lowest: compounds 2, 1 and 3 (each within the scatter of the next).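

In this assay, methyl in place of hydrogen on an oxygen whose other neighbour is a double-bonded nitrogen gives a 2.0-fold higher number from compound 2 to compound 3 (0.30 log units; within the scatter) and so does not separate hydroxy from methoxy. The comparison of the two alkyl groups on this oxygen gives no change at the digits printed from compound 1 to compound 3 (within the scatter) and adds a second direct reading at this position, so that hydrogen, methyl and ethyl now all stand within the scatter of one another, where the earlier pair covered only hydrogen and ethyl. No measurement among these compounds accounts for these numbers.

Going by these compounds, whether a longer chain such as butyl, or a chain ending in an amine or a carboxylic acid, on this same oxygen would move the number in this assay beyond the scatter remains open. Also open, on these data alone, is whether the same lack of separation among hydrogen, methyl and ethyl would hold on a different core, since all three compounds share the core of compound 1 and differ only on this oxygen.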